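A few compounds are considered here, and "the series" means these few. Any claim that something is new, unique, unknown or untested is made for them only; others in the source may bear on it.

Notes on the series. Compound 1 `CCCCCCCCCCCCCCCCO[P@]1(=O)OC[C@@H]2COC(=O)C2=C(C)O1` is the starting point of the step under consideration; the two other compounds measured alongside it are compound 2 `CC(C)COc1nn(-c2ccc(Oc3ccccc3)cc2)c(=O)o1` and compound 3 `CCCCCCOc1nn(-c2ccccc2)c(=O)o1`. In a functional assay on RAW264.7 cells (Mus musculus) for cytotoxicity (a lower number here means that less compound is tolerated, a higher number that more compound is tolerated), compound 1 gives > 100000 nM, which is a limit of the assay rather than a number. In this assay compound 2 gives > 100000 nM, again a limit. Compound 3 gives > 100000 nM in this assay, also a limit. Compound 1 thus stands where every value so far stands, at the limit of > 100000 nM in this assay, at which 3 of the 3 values shown sit, so no measured value separates any two of these compounds and nothing can be said about order among them.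

Compound 4 `CCCCCCCCCCCCCCCCO[P@]1(=O)OC[C@H]2COC(=O)C2=C(C)O1` has not yet been measured. It differs from compound 1 as follows: the two compounds have the same atoms and bonds and differ only in configuration as drawn: 1 of 2 stereo elements differ; a stereocentre at a saturated ring carbon is drawn S in compound 1 and R in compound 4. Among the measured compounds shown here, no step between two measured compounds exists, so there is no measured change to compare against. Since the change leaves atoms and bonds untouched, no step beyond the scatter is expected in this assay, in either direction. Compound 4 is expected to give 100000 nM in this assay, within a range from 50000 nM to 300000 nM. The step of a number no higher from compound 1 to compound 4 (the limit leaves the size open) that this estimate means is expected to sit within the scatter, and a limit rather than a number is the likely outcome for compound 4 because compound 1 itself sits at the limit of > 100000 nM in this assay, at which 3 of the 3 values shown sit.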

Compound 4, half-maximal cytotoxic concentration: > 100000 nM
Compound 4: only a limit was reported (the forecaster's own chance of this, stated with the estimate: 85%); the middle value sits exactly at the limit.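

The step between compound 1 and compound 4 cannot be read in this assay, because both results are limits of the assay rather than numbers: the limit of > 100000 nM in this assay, at which 4 of the 4 values shown sit.

On these data alone, whether the configuration at the saturated ring carbon makes any difference to the tolerated concentration in this assay stays open, as does the order among all four compounds.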